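The compounds below may be only part of what the source reports. "The series", "measured", "known", "first", "only" and "open" are said of these compounds alone.

Compound 1 `COc1cccc(/C=C2\CCC/C(=C\c3ccc(Cl)cc3)C2=O)c1OC` gives 18600 nM in an ADME assay on NHDF cells (Homo sapiens) for cytotoxicity, read by MTT assay, with a stated time of 72 h; a higher number here means a weaker inhibitor, a lower number a stronger inhibitor.
Compound 2 `COc1cccc(/C=C2\CCC/C(=C\c3ccccc3Br)C2=O)c1OC` gives only a limit of the assay in this assay, namely > 50000 nM.

Compound 2 therefore stands at the upper edge of what this assay reports; its true number is not known, only that it lies at or past that limit (the limit of > 50000 nM in this assay, at which 1 of the 2 values shown sits). The unmeasured compound 3 `COc1cccc(/C=C2\CCC/C(=C\c3cccc(O)c3)C2=O)c1OC` differs from compound 2 in one place: 3-hydroxyphenyl in place of 2-bromophenyl on a double-bonded chain carbon bound to a double-bonded ring carbon. For the measured compounds named here, the only measured step here, an at least 2.6-fold higher number from compound 1 to compound 2 (0.42 log units; beyond the scatter), concerns a different exchange of aryl groups, from a chlorine-bearing ring to a bromine-bearing one, and so speaks to this new change only loosely. Going by the values given here, both measured compounds are weak in this assay, and the hydroxyl-bearing ring of compound 3 has no measured counterpart among them. The expectation is that compound 3 stays in the same weak region, with a step of an at least 1.4-fold lower number from compound 2 to compound 3 (0.15 log units; that floor lies within the scatter) that is as likely to fall within the scatter as beyond it. The estimate for compound 3 in this assay is 35000 nM, with a range from 12000 nM to 100000 nM, and a real chance that only a limit is reported again.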

Compound 3, half-maximal inhibitory concentration: 19300 nM
For compound 3 the middle estimate is 1.8-fold (0.26 log units) above the measured one; the measured number falls inside the stated range.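

At this position on the double-bonded chain carbon, the change in this assay runs opposite to the one seen before: 3-hydroxyphenyl in place of 2-bromophenyl gives an at least 2.5-fold lower number from compound 2 to compound 3 (0.41 log units; beyond the scatter). For compound 2 the value of > 50000 nM is a limit of the assay and not a number, so this step gives only a floor for the true size of the change. Set against 4-chlorophenyl, 3-hydroxyphenyl gives a 1.0-fold higher number from compound 1 to compound 3 (0.02 log units; within the scatter), which lies within the scatter, so two rings that differ in their substituent and in its place read alike here, and compound 2 alone sits apart among the three.

On these data alone, it remains open whether compound 2 sits apart through the bromine itself or through where the bromine stands on the ring, as each of the three rings changes both at once. How a ring carrying an amine or a carboxylic acid would read in this assay is also left open, as is whether any of these readings would hold on another type of cell.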